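The compounds below may be only part of what the source reports. "The series", "measured", "known", "first", "only" and "open" are said of these compounds alone.

Of the compounds shown here, three from the same series have been tested for how much of them cells tolerate. Compound 1 `CC(CCNC(=O)c1c(Cl)cncc1Cl)N1CCC(C(Oc2ncccc2Cl)c2ccc(C(F)(F)F)cc2)CC1` in an ADME assay on PBMC cells (Homo sapiens) for cytotoxicity (a lower number here means that less compound is tolerated, a higher number that more compound is tolerated), gives 16700 nM, the smallest of the three numbers shown, although neither of the other two stands apart from it by more than the usual scatter. Compound 2 `CC(CCNC(=O)c1c(Cl)cncc1Cl)N1CCC(C(Oc2ccncc2)c2ccc(Br)cc2)CC1` gives 31200 nM in this assay, and compound 3 `CCO/N=C(/c1ccc(Br)cc1)C1CCN(C2(CCNC(=O)c3c(Cl)cncc3Cl)CC2)CC1` gives 33000 nM in this assay; both of those readings lie within the scatter of compound 1, so no order among the three can be claimed.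

Compound 4 `COC(=O)c1cccc(OC(c2ccc(C(F)(F)F)cc2)C2CCN(C(C)CCNC(=O)c3c(Cl)cncc3Cl)CC2)n1` has not yet been measured. It differs from compound 1 in one place: 6-(methoxycarbonyl)pyridin-2-yl in place of 3-chloropyridin-2-yl on an oxygen on a saturated carbon. No pair of measured compounds that differ in a single place is available, so nothing shown here tells how such an exchange moves this kind of reading. Across the three compounds already measured, the tolerated amount stays within one narrow band despite several differences in structure. On that basis the step from compound 1 to compound 4 in this assay is expected to be small, a 1.1-fold higher number from compound 1 to compound 4 (0.03 log units; within the scatter), and not beyond the scatter in either direction. For compound 4 the expected reading in this assay is therefore 18000 nM, with a likely range from 8000 nM to 40000 nM.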

Compound 4, half-maximal cytotoxic concentration: 14600 nM
For compound 4 the middle estimate is 1.2-fold (0.09 log units) above the measured one; low and high end bracket the measured number.
By their numbers in this assay, from the lowest: compounds 4, 1, 2 and 3 (each within the scatter of the next, the first and the last beyond it).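

Among these compounds, compound 1 and compound 4 form the first pair that differs in only one place, so the effect of a single exchange can now be read directly. In this assay, replacing 3-chloropyridin-2-yl with 6-(methoxycarbonyl)pyridin-2-yl on the oxygen gives a 1.1-fold lower number from compound 1 to compound 4 (0.06 log units; within the scatter) and so leaves the two compounds indistinguishable. This place in the molecule therefore accepts a change to a group with more heavy atoms, from one hydrogen-bond acceptor to three, and from a chlorine to two oxygens with no reading beyond the scatter, although no measurement shown here offers an explanation for this.

This single pair cannot show whether the result would hold for other groups at this place or for the same exchange on a different core. A carboxylic acid in place of the methoxycarbonyl group, or an amine on the pyridine ring, could still move the tolerated amount beyond the scatter, and the compounds shown leave both possibilities open.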